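Swapping a Nitro for Two Chlorines on the Sulfonyl Arene

This account rests on a few compounds, and the source may have more. Where it says the series, first, only, none or still open, it means among the compounds named here.

Three measured compounds share one core and differ only in the aryl group on the sulfonyl sulfur. In a functional assay on HepG2 cells (Homo sapiens) for antiproliferative activity, read by MTT assay, with a stated time of 48 h (on this read-out lower numbers stand for stronger inhibition and higher numbers for weaker inhibition), compound 1 `CC(C)(C)c1ccc(S(=O)(=O)n2cc(/C=C/C(=O)c3ccncc3)c3ccccc32)cc1` gives 27000 nM. Compound 2 `O=C(/C=C/c1cn(S(=O)(=O)c2ccccc2[N+](=O)[O-])c2ccccc12)c1ccncc1` gives 31700 nM. Compound 3 `O=C(/C=C/c1cn(S(=O)(=O)c2ccc([N+](=O)[O-])cc2)c2ccccc12)c1ccncc1` gives 18300 nM, the lowest of the three numbers, although the gaps to the others, a 1.5-fold lower number from compound 1 to compound 3 (0.17 log units; within the scatter) and a 1.7-fold lower number from compound 2 to compound 3 (0.24 log units; within the scatter), remain within the scatter, as does a 1.2-fold higher number from compound 1 to compound 2 (0.07 log units; within the scatter). Compound 4 `O=C(/C=C/c1cn(S(=O)(=O)c2ccc(Cl)cc2Cl)c2ccccc12)c1ccncc1` differs from compound 3 by one change: 2,4-dichlorophenyl in place of 4-nitrophenyl on a sulfonyl sulfur. Every measured exchange of the aryl group on the sulfonyl sulfur left the number essentially unmoved, so no step beyond the scatter is expected in this assay, namely a 1.1-fold higher number from compound 3 to compound 4 (0.04 log units; within the scatter). Compound 4 is therefore estimated at 20000 nM, with a range from 8000 nM to 50000 nM.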

Compound 4, half-maximal inhibitory concentration: 14800 nM
The estimate for compound 4 lay 1.4-fold (0.13 log units) above the measured number; the measured number falls inside the stated range.
By their numbers in this assay, from the lowest: compounds 4, 3, 1 and 2 (each within the scatter of the next, the first and the last beyond it).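

In this assay, the 2,4-dichlorophenyl group gives the only step among these four compounds that lies beyond the scatter, and a modest one (a 2.1-fold lower number from compound 2 to compound 4 (0.33 log units; beyond the scatter)). The same group stays within the scatter against the other two aryl groups on the sulfonyl sulfur (a 1.2-fold lower number from compound 3 to compound 4 (0.09 log units; within the scatter)) and (a 1.8-fold lower number from compound 1 to compound 4 (0.26 log units; within the scatter)), so this position has shown only a small range of numbers. Nothing available explains these steps. Still open, from the compounds shown here alone, is whether an amine or a carboxylic acid on this aryl ring, or a longer chain in place of the ring, would move the number further.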